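This account rests on a few compounds, and the source may have more. Where it says the series, first, only, none or still open, it means among the compounds named here.

Compound 1 `O=C(Nc1cccc(-n2cc(-c3ccncc3)c(-c3ccc(Cl)c(O)c3)n2)c1)Nc1cccc(C(F)(F)F)c1` was tested in a functional assay on A549 cells (Homo sapiens) for inhibition, read by sulforhodamine B assay, with a stated time of 48 h (a lower number here means a stronger inhibitor of growth, a higher number a weaker inhibitor of growth), where compound 1 gives 1370 nM. Two companions frame that number. Compound 2 `COc1cc(-c2nn(-c3cccc(NC(=O)Nc4cc(C(F)(F)F)cc(C(F)(F)F)c4)c3)cc2-c2ccncc2)ccc1Cl` gives 527 nM in this assay, a number that lies beyond the scatter below that of compound 1. Compound 3 `COc1cc(-c2nn(-c3cccc(NC(=O)c4cccc(C(F)(F)F)c4)c3)cc2-c2ccncc2)ccc1Cl` gives 1870 nM, which stands within the scatter of the value of compound 1, so no order can be read between those two. Compound 1 thus sits among the higher numbers of the three, separated clearly only from compound 2.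

Compound 4 `O=C(Nc1cccc(-n2cc(-c3ccncc3)c(-c3ccc(Cl)c(O)c3)n2)c1)Nc1ccc(Cl)c(Cl)c1` differs from compound 1 in a single place: 3,4-dichlorophenyl in place of 3-(trifluoromethyl)phenyl on an amide-type nitrogen. Among the compounds with values here, no pair among the measured compounds carries this change, so nothing directly shows its effect. In the absence of such a step, the expected outcome is a step from compound 1 to compound 4 of about a 1.2-fold lower number from compound 1 to compound 4 (0.10 log units; within the scatter), which is no more than the usual scatter, in no firm direction. On that basis compound 4 is estimated to give 1100 nM in this assay, with a range from 400 nM to 3000 nM.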

Compound 4, concentration for 50% growth inhibition: 1010 nM
The estimate for compound 4 lay 1.1-fold (0.04 log units) above the measured number, and the stated range covers the measured number.
By their numbers in this assay, from the lowest: compounds 2, 4, 1 and 3 (each within the scatter of the next, the first and the last beyond it).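

In this assay, exchanging the group on an amide-type nitrogen gives a 1.4-fold lower number from compound 1 to compound 4 (0.13 log units; within the scatter), the first direct step at this place among the compounds shown. The two groups therefore cannot be told apart here, although the entering group, 3,4-dichlorophenyl, holds chlorine and the leaving group, 3-(trifluoromethyl)phenyl, holds fluorine. No measurement shown explains why the two groups read alike.

From the compounds shown here alone, it remains open whether this place would read the same with a phenyl ring carrying an amine or a carboxylic acid, or with a single chlorine. No pair differing in one place yet shows what any other part of these compounds contributes, including the hydroxy group on the core of compound 1.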